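Swapping a thiophene for a furan on a pyridine core

A few compounds are considered here, and "the series" means these few. Any claim that something is new, unique, unknown or untested is made for them only; others in the source may bear on it.

Compound 1 `Oc1cccc(-c2cc(-c3ccccc3)cc(-c3ccsc3)n2)c1` was tested in a functional assay on HL-60 cells (Homo sapiens) for cytotoxicity, read by ELISA, with a stated time of 2 days (on this read-out lower numbers stand for stronger inhibition and higher numbers for weaker inhibition), where compound 1 gives 10300 nM. Compound 2 `Oc1cccc(-c2cc(-c3ccccc3)cc(-c3ccco3)n2)c1` differs from compound 1 by one group, (furan-2-yl in place of thiophen-3-yl on an aromatic carbon), and in this assay compound 2 gives 9910 nM, a step of a 1.0-fold lower number from compound 1 to compound 2 (0.02 log units; within the scatter). Compound 3 `Oc1cccc(-c2cc(-c3ccccc3)nc(-c3ccsc3)c2)c1` is built from the same atoms as compound 1 joined differently; the difference between the two cores is not broken down here. In this assay compound 3 gives 12000 nM, which sits close to the numbers of compound 1 and compound 2.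

Compound 4 `Oc1cccc(-c2cc(-c3ccccc3)nc(-c3ccco3)c2)c1` has not been measured. It stands to compound 3 as compound 2 stands to compound 1: furan-2-yl in place of thiophen-3-yl on an aromatic carbon, the same change made at the same place on the core. Because the measured step of a 1.0-fold lower number from compound 1 to compound 2 (0.02 log units; within the scatter) hardly moved the number, the step from compound 3 to compound 4 is expected to be small as well, about a 1.0-fold lower number from compound 3 to compound 4 (0.02 log units; within the scatter). On that basis compound 4 is estimated to give 11500 nM in this assay, with a likely range from 6000 nM to 22000 nM.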

Compound 4, half-maximal inhibitory concentration: 24000 nM
Compound 4: the middle estimate sits 2.1-fold (0.32 log units) below what was measured, outside the stated range (above it).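

In this assay, furan-2-yl in place of thiophen-3-yl on the core of compound 3 gives a 2.0-fold higher number from compound 3 to compound 4 (0.30 log units; within the scatter), so this step, like the earlier one on the core of compound 1, stays within the scatter. Set side by side, the two steps cannot be told apart: the same change on two cores in this assay, a 1.0-fold lower number (0.02 log units; within the scatter) from compound 1 to compound 2 and a 2.0-fold higher number (0.30 log units; within the scatter) from compound 3 to compound 4, 2.1-fold (0.32 log units) apart, within the scatter of two such steps. This fits a change that carries from one core to the other with little consequence for the read-out, but it rests on one pair per core, and neither step is large enough to show that a real effect transfers, nor does it say anything about cores beyond these two.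

The compounds shown leave open whether a furan-3-yl group would behave as furan-2-yl does, since the swap alters the hetero atom and the point of attachment together. They also leave open whether an amine or a carboxylic acid at the same place on the core would move the number beyond the scatter.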